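Aryl ester exchange on a flavone scaffold: tolerance outlook

The compounds below may be only part of what the source reports. "The series", "measured", "known", "first", "only" and "open" are said of these compounds alone.

Two esters of a shared flavone core have been examined. In an ADME assay on cells (T-cell, Mus musculus, strain BALB/c) for cytotoxicity, read by MTT assay, with a stated time of 48 h (a lower number here means that less compound is tolerated, a higher number that more compound is tolerated), compound 1 `COC(=O)c1c(Cl)cc(Cl)cc1OC(=O)COc1cc(O)c2c(=O)cc(-c3ccccc3)oc2c1` gives 345000 nM. In this assay compound 2 `COC(=O)c1cc(F)ccc1OC(=O)COc1cc(O)c2c(=O)cc(-c3ccccc3)oc2c1` gives 389000 nM, the top of the two numbers, although compound 1 lies within the scatter of it. Compound 3 `COC(=O)c1c(Cl)cccc1OC(=O)COc1cc(O)c2c(=O)cc(-c3ccccc3)oc2c1` is still unmeasured; it differs from compound 2 by a group of 11 heavy atoms (8 carbon, 2 oxygen, 1 chlorine; one six-membered aromatic ring of carbon only) in place of a group of 11 heavy atoms (8 carbon, 2 oxygen, 1 fluorine; one six-membered aromatic ring of carbon only), on an oxygen next to a carbonyl group. Among the compounds with values here, no step between measured compounds exists. Since compound 1 and compound 2 sit so close, the expected step of a 1.1-fold lower number from compound 2 to compound 3 (0.03 log units; within the scatter) is none beyond the scatter. Compound 3 is therefore estimated at 360000 nM, with a range from 180000 nM to 720000 nM.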

Compound 3, half-maximal cytotoxic concentration: 366000 nM
Compound 3: middle estimate off by 1.0-fold (0.01 log units), on the low side; low and high end bracket the measured number.
By their numbers in this assay, from the lowest: compounds 1, 3 and 2 (each within the scatter of the next).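

In this assay, the aryl group with chlorine in place of the one with fluorine, on this oxygen, gives a 1.1-fold lower number from compound 2 to compound 3 (0.03 log units; within the scatter), and hydrogen in place of chloro on an aromatic carbon gives a 1.1-fold higher number from compound 1 to compound 3 (0.03 log units; within the scatter). Within the data shown here, neither change moves the number beyond the scatter, which compound 1 and compound 2 could not show, as no single step joined them. No measurement here explains this closeness. The compounds shown leave open whether an amine or a carboxylic acid on this aryl ring, or a longer chain on the ester, would give a number beyond the scatter.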